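Removing the Ring Methyl from Compound 2

The compounds below may be only part of what the source reports. "The series", "measured", "known", "first", "only" and "open" are said of these compounds alone.

The measured compounds are compound 1 `CCCCOC(=O)Nc1ccc(S(=O)(=O)N2C[C@H](c3ccccc3)NC2=O)cc1CC` with 200 nM, compound 2 `CCOC(=O)Nc1ccc(S(=O)(=O)N2C(=O)N[C@@H](c3ccccc3)C2C)cc1Cl` with 6000 nM and compound 3 `CCc1cc(S(=O)(=O)N2C[C@H](c3ccccc3)NC2=O)ccc1NC(=O)OC(C)C` with 60 nM, all in a functional assay on NCI-H460 cells (Homo sapiens) for cytotoxicity, read by MTT assay; on this read-out higher numbers stand for weaker inhibition and lower numbers for stronger inhibition.

Among these three, compound 2 has the highest number; compound 1 and compound 3 both sit well below it. Among the measured compounds shown here, the one step between compounds that differ in a single place is a 3.3-fold lower number from compound 1 to compound 3 (0.52 log units; beyond the scatter), and it concerns the alkyl on the carbamate oxygen, not the ring.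

Compound 4 `CCOC(=O)Nc1ccc(S(=O)(=O)N2C[C@H](c3ccccc3)NC2=O)cc1Cl` is not yet measured. It differs from compound 2 by hydrogen in place of methyl on a saturated ring carbon. For the measured compounds named here, no measured step covers this change, so the expectation rests only on the fact that compound 1 and compound 3, which carry a hydrogen at that ring carbon, give far lower numbers than compound 2, although they also differ from compound 2 elsewhere. A lower number is therefore expected, but with wide uncertainty. The expected step is an 8.6-fold lower number from compound 2 to compound 4 (0.93 log units; beyond the scatter). For compound 4 the estimate is 700 nM, within a range from 150 nM to 3500 nM.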

Compound 4, half-maximal inhibitory concentration: 20 nM
The estimate for compound 4 lay 35-fold (1.54 log units) above the measured number; measured number below the stated range.
By their numbers in this assay, from the lowest: compound 4; then compound 3; then compound 1; then compound 2.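

In this assay, hydrogen in place of methyl on the saturated ring carbon gives a 300-fold lower number from compound 2 to compound 4 (2.48 log units; beyond the scatter), so this single position accounts for a large step on its own. The earlier compounds shown here could not show this, as those with hydrogen at this carbon also differ from compound 2 elsewhere. The change involves only 1 heavy atom and no hydrogen-bond donors, acceptors or net charge, and nothing shown here explains the size of the step.

The compounds shown leave open how an ethyl or a hydroxymethyl group at this ring carbon would compare, as only methyl and hydrogen appear there. They also leave open whether the step would keep its size with a butyl or isopropyl group on the carbamate oxygen, or with ethyl in place of the chlorine.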